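The source may report more compounds than this note shows. Statements on the series, on what has been measured and on what is new or still open speak of the compounds shown alone.

Measured compounds in an ADME assay on microsomes from liver (Mus musculus) for metabolic stability, read by LC-MS, using NADPH, tested at 10 uM; on this read-out higher numbers stand for a longer-lived compound and lower numbers for a shorter-lived compound:

compound 1 `O=C(NCc1ccc(F)cc1)c1ccc(N2CCN(S(=O)(=O)c3cccnc3O)CC2)nn1`: 1.2 h
compound 2 `Cc1ccc(F)cc1S(=O)(=O)N1CCN(c2ccc(C(=O)NCc3ccc(F)cc3)nn2)CC1`: 1.13 h
compound 3 `Cc1ccccc1S(=O)(=O)N1CC=C(c2ccc(C(=O)NCc3ccc(F)cc3)nn2)CC1`: 0.0833 h

Compound 2 gives 1.13 h in this assay, the second highest of the three numbers. Its nearest neighbour is compound 1 at 1.2 h, and the furthest is compound 3 at 0.0833 h. Among the measured compounds shown here, the one single-site step among the measured compounds, a 1.1-fold lower number from compound 1 to compound 2 (0.03 log units; within the scatter), swaps the group on the sulfonyl sulfur and stays within the scatter. Compound 3 differs from compound 2 in more than one place, so its much lower number cannot be tied to any one change.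

Compound 4 `Cc1nc(C(F)(F)F)ccc1S(=O)(=O)N1CCN(c2ccc(C(=O)NCc3ccc(F)cc3)nn2)CC1` is the next compound. Its difference from compound 2 is 2-methyl-6-(trifluoromethyl)pyridin-3-yl in place of 5-fluoro-2-methylphenyl on a sulfonyl sulfur. For the measured compounds named here, the only step that bears on this change is the one from compound 1 to compound 2, which also replaced the group on the sulfonyl sulfur and produced no shift beyond the scatter. On that basis compound 4 is expected to show no step beyond the scatter, a 1.1-fold lower number from compound 2 to compound 4 (0.05 log units; within the scatter). Compound 4 is therefore estimated at 1 h, with a range of 0.4 h to 2.5 h.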

Compound 4, half-life: 0.383 h
The estimate for compound 4 lay 2.6-fold (0.42 log units) above the measured number; measured number outside the range, below it.
By their numbers in this assay, from the lowest: compound 3; then compound 4; then compounds 2 and 1 (each within the scatter of the next).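

In this assay, the group on the sulfonyl sulfur proves not to be interchangeable: 2-methyl-6-(trifluoromethyl)pyridin-3-yl gives a step beyond the scatter against 5-fluoro-2-methylphenyl (a 3.0-fold lower number from compound 2 to compound 4 (0.47 log units; beyond the scatter)) and against 2-hydroxypyridin-3-yl (a 3.1-fold lower number from compound 1 to compound 4 (0.50 log units; beyond the scatter)). Both steps are modest, but the earlier exchange at this place showed no such shift, so that exchange did not speak for every group here. Nothing measured here accounts for the lower number.

The entering group differs from 5-fluoro-2-methylphenyl in both its ring and its substituents, so the compounds shown do not separate the contribution of the ring nitrogen from that of the trifluoromethyl. From the compounds shown here alone, it remains open whether a 2-methylpyridin-3-yl group, without the trifluoromethyl, would read like compound 2 or like compound 4.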